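Dichlorophenyl Sulfone Variant of a Serotonin Receptor Antagonist

The source may report more compounds than this note shows. Statements on the series, on what has been measured and on what is new or still open speak of the compounds shown alone.

Of the compounds shown here, three have been tested in a functional assay on HeLa cells for antagonist activity at 5-hydroxytryptamine receptor 6 (Homo sapiens); on this read-out higher numbers stand for larger maximal responses and lower numbers for smaller maximal responses. Compound 1 `CC(C)n1nc(S(=O)(=O)c2cccc3ccccc23)c2cc(N3CCN(C)CC3)ccc21` gives 98%. Compound 2 `Cc1ccc(S(=O)(=O)c2n[nH]c3ccc(N4CCN(C)CC4)cc23)cc1` gives 100%, and compound 3 `Cn1nc(S(=O)(=O)c2ccccc2)c2cc(N3CCNCC3)ccc21` gives 100%. Compound 2 stands level with compound 3 at the digits shown, the two together holding the highest figure, and the number for compound 1 differs from it only by an amount within the usual scatter. All three reach essentially a full response. Compound 4 `CN1CCN(c2ccc3[nH]nc(S(=O)(=O)c4c(Cl)cccc4Cl)c3c2)CC1` has not yet been measured in this assay. It differs from compound 2 in one place: 2,6-dichlorophenyl in place of 4-methylphenyl on a sulfonyl sulfur. Since compound 2 gives 100% and every tested compound reaches the same full response, the expected step is a number 2 percentage points lower from compound 2 to compound 4 (within the scatter), meaning none beyond the scatter. Compound 4 is estimated to reach 98%, within a range from 85% to 105%.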

Compound 4, largest response reached (reported as Imax), in percent of the reference or control that the assay uses: 100%
Compound 4: middle estimate off by 2 percentage points, on the low side; the measured number falls inside the stated range.
By their numbers in this assay, from the lowest: compounds 1, 2, 3 and 4 (each within the scatter of the next).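

In this assay, going by these compounds alone, replacing 4-methylphenyl with 2,6-dichlorophenyl on a sulfonyl sulfur brings no change at the digits printed from compound 2 to compound 4 (within the scatter) and gives the first comparison here of compounds that differ in one place. This place therefore accepts either group with the same full response. Nothing shown here explains this result. From the compounds shown here alone, whether an amine or a carboxylic acid on the same sulfonyl sulfur would keep that response remains open. With all four values this close, the compounds do not show which groups this place would not accept.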